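The compounds below may be only part of what the source reports. "The series", "measured", "known", "first", "only" and "open" are said of these compounds alone.

Of the compounds shown here, three sharing a common core have been measured in a functional assay on MDA-MB-231 cells (Homo sapiens) for inhibition, read by MTT assay, with a stated time of 48 h; on this read-out higher numbers stand for weaker inhibition and lower numbers for stronger inhibition. Compound 1 `Cc1nc(N(C)c2ccc([Se]C#N)c(Cl)c2)c2ccccc2n1` gives 9 nM. Compound 2 `COc1ccc(N(C)c2nc(C)nc3ccccc23)cc1C(=O)OCCC[Se]C#N` gives 1180 nM, the highest of the three numbers, and compound 3 `COc1ccc(N(C)c2nc(C)nc3ccccc23)cc1C(=O)OCCCCC[Se]C#N` gives 851 nM. Within the data shown here, the only single-point step among them, a 1.4-fold lower number from compound 2 to compound 3 (0.14 log units; within the scatter), lies within the scatter, so a longer or shorter chain at that end of the molecule made no visible difference. Compound 4 `COc1ccc(N(C)c2nc(C)nc3ccccc23)cc1OCCCC[Se]C#N` has not yet been measured. Relative to compound 2 it carries a group of 8 heavy atoms (5 carbon, 1 nitrogen, 1 oxygen, 1 selenium; no ring) in place of a group of 9 heavy atoms (5 carbon, 1 nitrogen, 2 oxygen, 1 selenium; no ring), on an aromatic carbon. The step from compound 2 to compound 3 is the only one that bears on this: it also exchanged one chain for another of similar make-up on the same side of the core, and it was small. Compound 1 differs from compound 2 in more than one place and gives no direct guidance. No step beyond the scatter is therefore expected. Compound 4 is expected to give 950 nM, with a range from 320 nM to 2900 nM, an estimated step of a 1.2-fold lower number from compound 2 to compound 4 (0.09 log units; within the scatter).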

Compound 4, half-maximal inhibitory concentration: 1350 nM
Compound 4: the middle estimate sits 1.4-fold (0.15 log units) below what was measured, within the range that was stated.
By their numbers in this assay, from the lowest: compound 1; then compounds 3, 2 and 4 (each within the scatter of the next).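

In this assay, the chain on this aromatic carbon, ortho to a methoxy group, loses its carbonyl, with the group of 8 heavy atoms in place of the group of 9, and the result is a 1.1-fold higher number from compound 2 to compound 4 (0.06 log units; within the scatter), so the carbonyl shows no visible contribution to the number in this pair. Earlier, a 1.4-fold lower number from compound 2 to compound 3 (0.14 log units; within the scatter) showed only that altering the chain while keeping its carbonyl link made no visible difference, whereas this step shows that the link itself can be altered with the same outcome. The data offer no measured explanation for this lack of response. From the compounds shown here alone, whether an amide or amine link at this aromatic carbon would also leave the number unmoved stays open. So does what happens when a carboxylic acid replaces the selenium and nitrile end of the chain.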